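The compounds below may be only part of what the source reports. "The series", "measured", "known", "first", "only" and "open" are said of these compounds alone.

In a functional assay on A549 cells (Homo sapiens) for cytotoxicity, read by MTT assay, with a stated time of 24 h, tested at 10 uM (a higher number here means a weaker effect of the compound at the concentration tested, a lower number a stronger effect), three compounds have been measured so far:
compound 1 `CCCCCCCCCCCCOC(=O)CCC(=O)N1CCN(CCCOc2cc3c(Nc4ccc(F)c(Cl)c4)ncnc3cc2OC)CC1` gives 95.5%;
compound 2 `CCCCCCCCCCCCCCOC(=O)CCC(=O)N1CCN(CCCOc2cc3c(Nc4ccc(F)c(Cl)c4)ncnc3cc2OC)CC1` gives 100%;
compound 3 `CCCCCCCCCCCCCCCOC(=O)CCC(=O)N1CCN(CCCOc2cc3c(Nc4ccc(F)c(Cl)c4)ncnc3cc2OC)CC1` gives 92%.

All three share one core and differ only in the length of a saturated chain. Compound 3 sits at the lower end of the three numbers, but a number 3.5 percentage points lower from compound 1 to compound 3 (within the scatter) and a number 8 percentage points lower from compound 2 to compound 3 (within the scatter), so the three read as alike. Compound 4 `CCCCCCCCCCCCCCCCCOC(=O)CCC(=O)N1CCN(CCCOc2cc3c(Nc4ccc(F)c(Cl)c4)ncnc3cc2OC)CC1` is reached from compound 3 by ethyl in place of hydrogen on a saturated chain carbon, ten or more bonds along the chain from an oxygen next to a carbonyl group. The same kind of chain lengthening has been seen three times: a number 4.5 percentage points higher from compound 1 to compound 2 (within the scatter), a number 3.5 percentage points lower from compound 1 to compound 3 (within the scatter) and a number 8 percentage points lower from compound 2 to compound 3 (within the scatter), none beyond the scatter. No step beyond the scatter is therefore expected in this assay: a number 3 percentage points higher from compound 3 to compound 4 (within the scatter). Compound 4 is estimated at 95%, within 85% to 105%.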

Compound 4, a percentage reported as activity, at one concentration (the size of the read-out at that concentration, not a potency): 95.7%
Beside the measured number, compound 4's estimate is 0.7 percentage points below it; the range from low to high includes it.
By their numbers in this assay, from the lowest: compounds 3, 1, 4 and 2 (each within the scatter of the next).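

Lengthening the saturated chain further still gives no step that stands out in this assay: a number 3.7 percentage points higher from compound 3 to compound 4 (within the scatter) and a number 4.3 percentage points lower from compound 2 to compound 4 (within the scatter) and a number 0.2 percentage points higher from compound 1 to compound 4 (within the scatter). What is new is that the ethyl change now appears at two chain lengths and gives matching steps: the same change on two cores in this assay, a number 4.5 percentage points higher (within the scatter) from compound 1 to compound 2 and a number 3.7 percentage points higher (within the scatter) from compound 3 to compound 4, 0.8 percentage points apart, within the scatter of two such steps. The propyl change repeats in the same way, so at this far end of the chain these added carbons show no effect on the read-out: the same change on two cores in this assay, a number 3.5 percentage points lower (within the scatter) from compound 1 to compound 3 and a number 4.3 percentage points lower (within the scatter) from compound 2 to compound 4, 0.8 percentage points apart, within the scatter of two such steps.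

Still open, on these data alone, is whether a much shorter chain or a much longer chain would read the same. An amine or a carboxylic acid at the chain end could also give a different number.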